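A few compounds are considered here, and "the series" means these few. Any claim that something is new, unique, unknown or untested is made for them only; others in the source may bear on it.

Measured so far in a functional assay on MGC-803 cells (Homo sapiens) for inhibition, read by MTT assay, with a stated time of 72 h; on this read-out lower numbers stand for stronger inhibition and higher numbers for weaker inhibition:

- compound 1 `Cc1cc(Nc2cc(-c3ccccc3)[nH]n2)n2nc(SCc3ccc([N+](=O)[O-])cc3)nc2n1`: 4250 nM
- compound 2 `Cc1cc(Nc2cc(-c3ccccc3)[nH]n2)n2nc(SCc3csc4ccccc34)nc2n1`: 2280 nM

On these two numbers compound 1 stands highest; its nearest neighbour is compound 2, with a 1.9-fold lower number from compound 1 to compound 2 (0.27 log units; within the scatter), so the two compounds are not separated. Among the measured compounds shown here, that single step exchanges the whole aryl group on the saturated chain carbon bound to the sulfur and is the only measured change.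

Compound 3 `Cc1cc(Nc2cc(-c3ccccc3)[nH]n2)n2nc(SCc3ccc(Cl)cc3)nc2n1` differs from compound 1 by chloro in place of nitro on an aromatic carbon. For the measured compounds named here, no measured step in this assay touches this exchange, and the one step that alters the same part of the molecule stayed within the scatter. Nothing therefore supports a sizeable move in either direction; the expected step is a 1.3-fold lower number from compound 1 to compound 3 (0.12 log units; within the scatter), essentially flat. For compound 3 in this assay the estimate is 3200 nM, with a range from 1200 nM to 8500 nM, reflecting the absence of any direct precedent for the change.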

Compound 3, half-maximal inhibitory concentration: 3950 nM
Compound 3: middle estimate off by 1.2-fold (0.09 log units), on the low side; the range from low to high includes it.
By their numbers in this assay, from the lowest: compounds 2, 3 and 1 (each within the scatter of the next).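

In this assay, among the compounds shown here, chloro in place of nitro on an aromatic carbon gives a 1.1-fold lower number from compound 1 to compound 3 (0.03 log units; within the scatter) and so puts a first direct exchange at this place on the ring: the two groups are not separated, although nitro brings 3 heavy atoms and 2 hydrogen-bond acceptors and chloro a single heavy atom and none. The exchange of the whole aryl group gives a 1.7-fold higher number from compound 2 to compound 3 (0.24 log units; within the scatter) and leaves 4-chlorophenyl and 1-benzothiophen-3-yl unseparated as well, so all three compounds lie within the scatter of one another. Nothing measured bears on the reason for this flat picture.

Going by these compounds, whether an amine or a carboxylic acid in place of the nitro would separate from these compounds remains open. So does the effect of a longer chain in place of the saturated chain carbon bound to the sulfur.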